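Trifluoromethyl in Place of Chloro on the Fused Ring

The compounds below may be only part of what the source reports. "The series", "measured", "known", "first", "only" and "open" are said of these compounds alone.

Compound 1 `NC(=S)N/N=C1/C(=O)N(CN2CCN(c3ccnc4cc(Cl)ccc34)CC2)c2cccc(Cl)c21` shows the lowest of the three numbers measured in an ADME assay on MCF-10A cells (Homo sapiens) for cytotoxicity, read by sulforhodamine B assay, with a stated time of 48 h (a higher number here means a weaker inhibitor of growth, a lower number a stronger inhibitor of growth), at 19800 nM, though only within the scatter of the other two. Compound 2 `NC(=S)N/N=C1/C(=O)N(CN2CCN(c3ccnc4cc(Cl)ccc34)CC2)c2cccc(Br)c21` gives 29400 nM and compound 3 `NC(=S)N/N=C1/C(=O)N(CN2CCN(c3ccnc4cc(Cl)ccc34)CC2)c2ccccc21` gives 27700 nM; the steps of a 1.5-fold higher number from compound 1 to compound 2 (0.17 log units; within the scatter), a 1.4-fold higher number from compound 1 to compound 3 (0.15 log units; within the scatter) and a 1.1-fold lower number from compound 2 to compound 3 (0.03 log units; within the scatter) all lie within the scatter, so the three stand level. Compound 4 `NC(=S)N/N=C1/C(=O)N(CN2CCN(c3ccnc4cc(C(F)(F)F)ccc34)CC2)c2cccc(Cl)c21` differs from compound 1 by trifluoromethyl in place of chloro on an aromatic carbon. Going by the values given here, no measured step touches that fused ring; each concerns an aromatic carbon of the other ring, and each stayed within the scatter. With no measured change bearing directly on this exchange, the expected step is a 1.0-fold higher number from compound 1 to compound 4 (0.00 log units; within the scatter) in this assay, none beyond the scatter. Compound 4 is estimated at 20000 nM, within 8000 nM to 50000 nM.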

Compound 4, concentration for 50% growth inhibition: 51700 nM
The estimate for compound 4 lay 2.6-fold (0.41 log units) below the measured number; measured number outside the range, above it.
By their numbers in this assay, from the lowest: compounds 1, 3, 2 and 4 (each within the scatter of the next, the first and the last beyond it).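

Trifluoromethyl in place of chloro on this aromatic carbon gives the only step here beyond the scatter: in this assay there is a 2.6-fold higher number from compound 1 to compound 4 (0.42 log units; beyond the scatter). Going by these compounds alone, the exchanges on the other ring stayed within the scatter, so this position is the first to show a response, though a modest one, towards weaker growth inhibition. No supporting measurement bears on the reason for this step. The compounds shown leave open what fluoro, methoxy or an amine at this carbon would give, and whether trifluoromethyl here gives a like step with bromo or hydrogen on the other ring.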